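A Halogen Swap Repeated on a Second Core

This account rests on a few compounds, and the source may have more. Where it says the series, first, only, none or still open, it means among the compounds named here.

Measured compounds in a functional assay on A549 cells (Homo sapiens) for antiproliferative activity, read by MTT assay, with a stated time of 24 h; a higher number here means a weaker inhibitor, a lower number a stronger inhibitor:
compound 1, `O=C(NNC(=O)c1cccc(NS(=O)(=O)c2cnc(O)nc2O)c1)c1cccc(Cl)c1`: 6000 nM
compound 2, `O=C(NNC(=O)c1ccccc1F)c1cccc(NS(=O)(=O)c2cnc(O)nc2O)c1`: 10800 nM
compound 3, `O=C(NNC(=O)c1ccccc1NS(=O)(=O)c1cnc(O)nc1O)c1cccc(Cl)c1`: 1260 nM

Compound 1 and compound 3 are built from the same atoms joined differently; the difference between the two cores is not broken down here. Compound 3 gives the lowest number of the three, with its nearest neighbour compound 1 and compound 2 further away, both beyond the scatter, so compound 3 stands as the strongest inhibitor in this assay among the measured set.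

From compound 1 to compound 2 the change is 2-fluorophenyl in place of 3-chlorophenyl on a carbonyl carbon, and it made a 1.8-fold higher number from compound 1 to compound 2 (0.26 log units; within the scatter). The unmeasured compound 4, `O=C(NNC(=O)c1ccccc1NS(=O)(=O)c1cnc(O)nc1O)c1ccccc1F`, carries the same change on the core of compound 3: 2-fluorophenyl in place of 3-chlorophenyl on a carbonyl carbon. The two place descriptions read alike, so this is the same change on a different core.

Because the earlier instance gave a 1.8-fold higher number from compound 1 to compound 2 (0.26 log units; within the scatter), compound 4 is expected to show a step of about a 1.7-fold higher number from compound 3 to compound 4 (0.24 log units; within the scatter) from compound 3. Compound 4 is therefore estimated at 2200 nM in this assay, with a range from 900 nM to 6000 nM.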

Compound 4, half-maximal inhibitory concentration: 7150 nM
Estimate against measurement, compound 4: 3.3-fold (0.51 log units) below, and the stated range ends below it.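

In this assay, 2-fluorophenyl in place of 3-chlorophenyl on a carbonyl carbon gave a 5.7-fold higher number from compound 3 to compound 4 (0.75 log units; beyond the scatter), and the same change did not give steps of the same size on the two cores: the same change on two cores in this assay, a 1.8-fold higher number (0.26 log units; within the scatter) from compound 1 to compound 2 and a 5.7-fold higher number (0.75 log units; beyond the scatter) from compound 3 to compound 4, 3.2-fold (0.50 log units) apart, beyond the scatter of two such steps The size of the step seen on the core of compound 1 therefore did not carry over to the core of compound 3, so in this series a step read on one of these cores is a poor guide to the other. With one pair on each core, this shows that the outcome of the change depends on the core it sits on, but it does not show what in the two cores sets the steps apart, or whether other changes would behave the same way.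

On these data alone, only 3-chlorophenyl and 2-fluorophenyl appear at this carbonyl carbon, so it remains open how an unsubstituted phenyl, a methoxyphenyl or an aminophenyl would fare there on either core. Also open, as far as these compounds go, is whether the gap between the two steps would hold on a third core.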